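The source may hold more compounds than are shown below. What is called first, only, known or untested is meant among the compounds shown, and "the series" means these compounds.

In a functional assay on HepG2 cells (Homo sapiens) for antiproliferative activity, read by MTT assay, with a stated time of 48 h (a lower number here means a stronger inhibitor, a higher number a weaker inhibitor), compound 2 `COc1ccc(-c2c(Nc3ccc(F)cc3)c3ccc(OC)cc3oc2=O)cc1` gives > 100000 nM, and this is the limit of > 100000 nM in this assay, at which 1 of the 3 values shown sits. Compound 1 `COc1ccc(-c2c(Nc3ccc(F)cc3)c3ccccc3oc2=O)cc1`, which lacks the added methoxy, gives 35500 nM. Compound 3 `COc1ccc(-c2c(Nc3ccc(C)c(O)c3)c3ccc(OC)cc3oc2=O)cc1`, which carries 3-hydroxy-4-methylphenyl on the nitrogen, gives 22500 nM. Compound 4 `COc1ccc(-c2c(Nc3ccc(F)cc3)c3ccc(O)cc3oc2=O)cc1` keeps the 4-fluorophenyl of compound 2 but has hydrogen in place of methyl on an oxygen on an aromatic ring, methoxy to hydroxy: hydrogen in place of methyl on an oxygen on an aromatic ring. The closest guide is an at least 2.8-fold higher number from compound 1 to compound 2 (0.44 log units; beyond the scatter), while an at least 4.4-fold lower number from compound 2 to compound 3 (0.64 log units; beyond the scatter) shows that a change elsewhere can also bring the number down. A modest move to a lower number in this assay is therefore expected, as an at least 2.0-fold lower number from compound 2 to compound 4 (0.30 log units; that floor lies within the scatter). For compound 4 the estimate is 50000 nM, with an expected range from 15000 nM to 150000 nM.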

Compound 4, half-maximal inhibitory concentration: 65600 nM
Estimate against measurement, compound 4: 1.3-fold (0.12 log units) below; the measured number falls inside the stated range.
By their numbers in this assay, from the lowest: compounds 3, 1 and 4 (each within the scatter of the next, the first and the last beyond it). At a limit, above all of these: compound 2.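

Hydrogen in place of methyl on the oxygen on the aromatic ring gives an at least 1.5-fold lower number from compound 2 to compound 4 (0.18 log units; that floor lies within the scatter). Going by these compounds, compound 2 stands at a limit, so the full size of this step stays unknown: the limit of > 100000 nM in this assay, at which 1 of the 4 values shown sits. Hydroxy in place of hydrogen on the aromatic carbon gives a 1.8-fold higher number from compound 1 to compound 4 (0.27 log units; within the scatter), whereas methoxy at that place gave an at least 2.8-fold higher number from compound 1 to compound 2 (0.44 log units; beyond the scatter), so only the methoxy step is clearly beyond the scatter.

On these data alone, how an amine or a carboxylic acid on that carbon would compare remains open. So does how a longer chain on the oxygen would compare.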